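Two Inactive Sulfonyl Compounds and an Untested Amide

A few compounds are considered here, and "the series" means these few. Any claim that something is new, unique, unknown or untested is made for them only; others in the source may bear on it.

- Compound 1 `Cc1cc(C)c(S(=O)(=O)N2CCC(N3CCCCCC3)CC2)c(C)c1`: > 5000 nM (a limit)
- Compound 2 `Cc1cc(C)c(S(=O)(=O)c2ccc(N3CCC(C)CC3)cc2)c(C)c1`: > 5000 nM (a limit)

In an ADME assay on HCT-116 cells (Homo sapiens) for cytotoxicity, read by CellTiter-Glo, with a stated time of 72 h (on this read-out lower numbers stand for stronger inhibition and higher numbers for weaker inhibition), compound 1 gives > 5000 nM, which is a limit of the assay and not a number. Compound 2 gives > 5000 nM, also a limit. Compound 1 can therefore be placed only at the limit of > 5000 nM in this assay, at which 2 of the 2 values shown sit.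

Compound 3 `Cc1cc(C)c(S(=O)(=O)N2CCC(C(=O)N3CCC(C)CC3)CC2)c(C)c1` keeps the core of compound 1 but carries (4-methylpiperidin-1-yl)carbonyl in place of azepan-1-yl on a saturated ring carbon. Going by the values given here, the only starting point is compound 1 at > 5000 nM, so no step beyond the usual scatter is expected in this assay, in either direction. The expected change is a step that the limit leaves unreadable from compound 1 to compound 3. For compound 3, the estimated value is 6000 nM, with an expected range from 2000 nM to 15000 nM.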

Compound 3, half-maximal inhibitory concentration: > 5000 nM
Compound 3 was reported as a limit; the forecaster's own chance of this, stated with the estimate: 80%; the middle value is on the limit's open side.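

Going by these compounds alone, no step from compound 1 to compound 3 can be read, as both results are limits of the assay and not numbers: the limit of > 5000 nM in this assay, at which 3 of the 3 values shown sit. The compounds shown leave open how far each lies past that limit, and which structural change, if any, would give a measurable value.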